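The source may hold more compounds than are shown below. What is called first, only, known or untested is meant among the compounds shown, and "the series" means these compounds.

In a functional assay on DU-145 cells (Homo sapiens) for cytotoxicity, read by MTT assay, with stated times of 48 h and 4 h (a higher number here means a weaker inhibitor, a lower number a stronger inhibitor), compound 1 `CCN(CC)CCNc1nc(/C=C/c2ccc(OC)c(OC)c2)nc2ccccc12` gives 31400 nM. Compound 2 `COc1ccc(/C=C/c2nc(NCCN(C(C)C)C(C)C)c3ccccc3n2)cc1OC` gives 15000 nM. Compound 3 `COc1ccc(/C=C/c2nc(NCCN(C(C)C)C(C)C)c3cc(Cl)ccc3n2)cc1OC` gives > 100000 nM, which is a limit of the assay and not a number.

Compound 4 `COc1ccc(/C=C/c2nc(NCCCCN)c3cc(Cl)ccc3n2)cc1OC` keeps the chloro of compound 3 and changes the side chain: 2-aminoethyl in place of diisopropylamino on a saturated chain carbon, two bonds along the chain from a nitrogen on an aromatic ring. Cut further out, the same difference reads (2-(diisopropylamino)ethyl)amino to (4-aminobutyl)amino.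

Going by the values given here, two measured steps bear on this change. The only one at this place, with diisopropylamino in place of diethylamino, is a 2.1-fold lower number from compound 1 to compound 2 (0.32 log units; beyond the scatter), and it is modest. The other, with chloro in place of hydrogen on an aromatic carbon, is an at least 6.6-fold higher number from compound 2 to compound 3 (0.82 log units; beyond the scatter), and it lies elsewhere on the molecule. Neither step replaces a tertiary amine with a primary one, so the size of the new step is poorly constrained. A modest move to a lower number is expected, given the modest size of a 2.1-fold lower number from compound 1 to compound 2 (0.32 log units; beyond the scatter) at this place. The expected change is an at least 2.8-fold lower number from compound 3 to compound 4 (0.45 log units; beyond the scatter). For compound 4 the estimated value is 35000 nM, with an expected range of 8000 nM to 100000 nM.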

Compound 4, half-maximal inhibitory concentration: 20000 nM
Compound 4: middle estimate off by 1.8-fold (0.24 log units), on the high side; the range from low to high includes it.
By their numbers in this assay, from the lowest: compounds 2, 4 and 1 (each within the scatter of the next, the first and the last beyond it). At a limit, above all of these: compound 3.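

With the chloro kept, replacing the (2-(diisopropylamino)ethyl)amino side chain with (4-aminobutyl)amino gives an at least 5.0-fold lower number from compound 3 to compound 4 (0.69 log units; beyond the scatter), so in this assay a terminal primary amine on this chain gives a measurable value where the diisopropylamino compound does not. The earlier step at this place, a 2.1-fold lower number from compound 1 to compound 2 (0.32 log units; beyond the scatter), exchanged one tertiary amine for another and showed only a modest change, whereas this one shows that a change of amine type and chain can move the number further. The true size of the new step stays unknown, as compound 3 sits at a limit of the assay and not at a number: the limit of > 100000 nM in this assay, at which 1 of the 4 values shown sits.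

Going by these compounds, in this pair, chain length and amine type change together, so their separate contributions remain open. Also open, on these data alone, are whether the step holds without the chloro and how a terminal hydroxyl, a carboxylic acid or a longer chain would read at this place.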